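The compounds below may be only part of what the source reports. "The series", "measured", "known", "first", "only" and "open" are said of these compounds alone.

Measured in a functional assay on U-251 cells (Homo sapiens) for antiproliferative activity, read by MTT assay, with a stated time of 48 h; on this read-out higher numbers stand for weaker inhibition and lower numbers for stronger inhibition:
- Compound 1 `COc1cc(-c2cccc3nc(-c4cccc(F)c4)oc23)cc(OC)c1OC`: 2900 nM
- Compound 2 `COc1cc(-c2cccc3nc(-c4ccc(Br)cc4)oc23)cc(OC)c1OC`: > 25000 nM (a limit of the assay, not a number)
- Compound 3 `COc1cc(-c2nc3cccc(-c4cc(OC)c(OC)c(OC)c4)c3o2)ccc1O`: 10300 nM

Only compound 1 and compound 3 have actual numbers, and compound 3 has the higher one, which means weaker inhibition. The gap between them is a 3.6-fold higher number from compound 1 to compound 3 (0.55 log units; beyond the scatter).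

Compound 4 `COc1cc(-c2cccc3nc(-c4ccc5cc[nH]c5c4)oc23)cc(OC)c1OC` has not been measured yet. It carries 1H-indol-6-yl in place of 4-hydroxy-3-methoxyphenyl on an aromatic carbon.

All three measured steps swap the group at this same place, so all of them bear on the question. Besides the step already given, there is an at least 8.6-fold higher number from compound 1 to compound 2 (0.93 log units; beyond the scatter), and also an at least 2.4-fold lower number from compound 2 to compound 3 (0.38 log units; beyond the scatter). Swaps here have therefore moved the number in both directions, by modest amounts or more. Among the measured compounds shown here, none of the measured compounds carries 1H-indol-6-yl, so these steps point to no clear direction.

The expectation therefore starts from compound 3 at 10300 nM, with no shift beyond the scatter and with wide margins. The expected change is a 1.3-fold lower number from compound 3 to compound 4 (0.11 log units; within the scatter). For compound 4 the estimated value is 8000 nM, with an expected range from 2500 nM to 25000 nM.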

Compound 4, half-maximal inhibitory concentration: 300 nM
Estimate against measurement, compound 4: 27-fold (1.43 log units) above; measured number below the stated range.
By their numbers in this assay, from the lowest: compound 4; then compound 1; then compound 3. At a limit, above all of these: compound 2.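

In this assay, putting 1H-indol-6-yl on this aromatic carbon gives a 34-fold lower number from compound 3 to compound 4 (1.54 log units; beyond the scatter) and a 9.7-fold lower number from compound 1 to compound 4 (0.99 log units; beyond the scatter), so this place can carry a group that gives much stronger inhibition than the three phenyl groups seen before, not just modest shifts in either direction. Compound 3 and compound 4 have the same number of heavy atoms and of hydrogen-bond donors, so those counts alone do not follow the change in activity; what differs is that the entering group has a second, five-membered aromatic ring holding nitrogen and has no hydrogen-bond acceptors. The remaining step, an at least 83-fold lower number from compound 2 to compound 4 (1.92 log units; beyond the scatter), starts from a value that is a limit and not a number: the limit of > 25000 nM in this assay, at which 1 of the 4 values shown sits.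

On these data alone, it stays open whether the gain depends on the hydrogen on the indole nitrogen, which a methyl group on that nitrogen would test. As far as these compounds go, it is also open whether the two-ring shape alone is enough, which a naphthyl group, made of carbon only, would separate from the effect of the ring nitrogen.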